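A Methyl Added to an Inactive Phosphoserine Ester

This account rests on a few compounds, and the source may have more. Where it says the series, first, only, none or still open, it means among the compounds named here.

Compound 1, `N[C@@H](COP(=O)(O)OC[C@H]1OCCC[C@H]1OC(=O)CCc1ccccc1OCc1cccc(Oc2ccccc2)c1)C(=O)O`: "not active" (no number reported)
Compound 2, `CCCCCCCCCCCOc1ccccc1CCC(=O)OC[C@H]1OCC=C[C@@H]1OP(=O)(O)OC[C@H](N)C(=O)O`: 0.071
Compound 3, `Cc1ccc(Oc2cccc(COc3ccccc3CCC(=O)OC[C@H]3OCCC[C@H]3OP(=O)(O)OC[C@H](N)C(=O)O)c2)cc1`: "not active" (no number reported)

In an assay on HEK293-A cells with putative P2Y purinoceptor 10 (Mus musculus) as the target, with a stated time of 1.5 h (a lower number here means a smaller maximal response, a higher number a larger maximal response), compound 1 gives "not active" (no number reported), with no number attached to it. Compound 3 likewise gives "not active" (no number reported) in this assay. Only compound 2 returns a number in this assay, namely 0.071, a small fraction of the reference response. For the measured compounds named here, no two of the measured compounds differ in a single place, so no measured step exists against which a change can be sized.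

Compound 4, `Cc1ccc(Oc2cccc(COc3ccccc3CCC(=O)O[C@@H]3CCCO[C@@H]3COP(=O)(O)OC[C@H](N)C(=O)O)c2)cc1`, is derived from compound 1 by methyl in place of hydrogen on an aromatic carbon. Because compound 1 stands at "not active" (no number reported) with no number, there is no starting value from which a step could be read, and the direction of the change cannot be taken from compound 1 and compound 3, both of which are without a number. The expectation for compound 4 is therefore a maximal response that stays at or near the bottom of the scale, most likely again reported without a number, and any difference from compound 1 is expected not to exceed the usual scatter. Compound 4 is estimated to give 0.04 in this assay, with a range from 0 to 0.15.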

Compound 4, intrinsic activity: the largest response reached, as a fraction of the reference agonist's: "not active" (no number reported)
For compound 4 the study gives words and no number, and the estimate cannot be compared.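

In this assay compound 1 gives "not active" (no number reported) and compound 4 gives "not active" (no number reported), so no step can be read for the methyl. Nothing measured here bears on a cause for this result. The compounds shown leave open whether this methyl changes the maximal response at all.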